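This account rests on a few compounds, and the source may have more. Where it says the series, first, only, none or still open, it means among the compounds named here.

For the measured compounds named here, in an ADME assay on the whole organism (Rattus norvegicus, strain Sprague-Dawley) for pharmacokinetics, read by LC-MS, with a stated time of 48 h, at a dose of 5 mg/kg by the intravenous route (a lower number here means less compound in the circulation, a higher number more compound in the circulation at the dose given), compound 2 (`CC#CCn1c(N2CCC[C@@H](N)C2)nc2c1c(=O)n(Cc1ccc(Br)cc1C(=O)O)c(=O)n2C`) stands highest with 23500 ng.h/mL on the numbers so far, and compound 1 (`CC#CCn1c(N2CCC[C@@H](N)C2)nc2c1c(=O)n(Cc1cc(Cl)ccc1C(=O)O)c(=O)n2C`) gives 4860 ng.h/mL as the only other value. For compound 3 (`CC#CCn1c(N2CCC[C@@H](N)C2)nc2c1c(=O)n(Cc1cc(OC)ccc1C(=O)O)c(=O)n2C`) the change is 2-carboxy-5-methoxyphenyl in place of 4-bromo-2-carboxyphenyl on a saturated chain carbon bound to an aromatic nitrogen and nothing else differs. Going by the values given here, the one measured step at this place is a 4.8-fold higher number from compound 1 to compound 2 (0.68 log units; beyond the scatter) and it rests on a single pair. Compound 3 gives up the 4-bromo-2-carboxyphenyl of compound 2, and the numbering of its 2-carboxy-5-methoxyphenyl matches the group on compound 1 (4860 ng.h/mL), so a fall of similar size is expected. The estimated step is a 3.6-fold lower number from compound 2 to compound 3 (0.56 log units; beyond the scatter) and points downward. Compound 3 is estimated at 6500 ng.h/mL with a range from 2500 ng.h/mL to 16000 ng.h/mL as the expected span.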

Compound 3, area under the concentration-time curve: 3930 ng.h/mL
Beside the measured number, compound 3's estimate is 1.7-fold (0.22 log units) above it; the measured number falls inside the stated range.
By their numbers in this assay, from the lowest: compounds 3 and 1 (each within the scatter of the next); then compound 2.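

In this assay, 2-carboxy-5-methoxyphenyl in place of 4-bromo-2-carboxyphenyl gives a 6.0-fold lower number from compound 2 to compound 3 (0.78 log units; beyond the scatter) and so repeats the drop seen against compound 2 with a second group. Methoxy in place of chloro on an aromatic carbon gives a 1.2-fold lower number from compound 1 to compound 3 (0.09 log units; within the scatter) and leaves the two numbers indistinguishable, so among these three compounds only compound 2 stands apart. The compounds shown leave open whether the higher number of compound 2 goes with the bromo itself or with its numbering on the ring, and how a nitrile or an amine in place of the methoxy would read. No measurement at hand explains these differences.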